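The source may hold more compounds than are shown below. What is called first, only, known or untested is meant among the compounds shown, and "the series" means these compounds.

Compound 1, `O=C(Nc1cccc(O)c1)c1nccc2ccccc12`, returns in a functional assay on NUGC-3 cells (Homo sapiens) for inhibition, read by sulforhodamine B assay, with a stated time of 48 h (a lower number here means a stronger inhibitor of growth, a higher number a weaker inhibitor of growth), a limit rather than a number: > 10000 nM. Compound 2, `O=C(Nc1ccc(C(F)(F)F)cc1)c1nccc2ccccc12`, likewise reaches only a limit in this assay, namely > 10000 nM. Compound 1 therefore stands at the limit of > 10000 nM in this assay, at which 2 of the 2 values shown sit, with no measured number that sets it apart from its companion. Compound 3, `O=C(Nc1cccc(Cl)c1)c1nccc2ccccc12`, has not yet been measured in this assay. It differs from compound 1 by chloro in place of hydroxy on an aromatic carbon, meta to a large group. Among the compounds with values here, no step between measured compounds is available here, so the size of this change cannot be read from the data. Because compound 1 and compound 2 both sit at the limit of > 10000 nM in this assay, at which 2 of the 2 values shown sit, the expected step is a step that the limit leaves unreadable from compound 1 to compound 3, none beyond the scatter, and the likely outcome is again a limit. Compound 3 is accordingly expected at 15000 nM, within 4000 nM to 60000 nM in this assay.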

Compound 3, concentration for 50% growth inhibition: > 10000 nM
Compound 3: a limit, no number; the forecaster's own chance of this, stated with the estimate: 70%; the middle value lies beyond the limit too.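

Compound 1 and compound 3 both return only a limit in this assay, so no step between them can be read: the limit of > 10000 nM in this assay, at which 3 of the 3 values shown sit.

The compounds shown leave open how compound 1, compound 2 and compound 3 truly rank, and which change to the shared core would yield a measured number in this assay.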